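A few compounds are considered here, and "the series" means these few. Any claim that something is new, unique, unknown or untested is made for them only; others in the source may bear on it.

In an assay on isolated protein for displacement of a labelled ligand from metabotropic glutamate receptor 5 (Homo sapiens), with a stated time of 60 min, tested at 1 uM (a lower number here means less inhibition, a higher number more inhibition at the concentration tested (going by the name of the read-out)), compound 1 `Cc1cc(C)cc(S(=O)(=O)c2cnc3cc(F)ccc3c2N2CCC(C)CC2)c1` gives 80%, the top number among the three compounds measured. Compound 3 `O=S(=O)(c1ccccc1)c1cnc2ccccc2c1N1CCCCCC1` gives 79.9% in this assay, a number within the usual scatter of that of compound 1, so the two cannot be told apart. Compound 2 `CC1CCN(c2c(S(=O)(=O)c3cc(F)cc(F)c3)cnc3c(F)cccc23)CC1` gives 9%, far beyond the scatter from compound 1. Compound 4 `Cc1ccc(S(=O)(=O)c2cnc3cc(F)ccc3c2N2CCC(C)CC2)cc1F` differs from compound 1 only in the group on the sulfonyl sulfur: 3-fluoro-4-methylphenyl in place of 3,5-dimethylphenyl on a sulfonyl sulfur. For the measured compounds named here, no measured pair shows this change alone, so its effect is unknown. Compound 2, which carries fluorines on its aryl sulfone, is the only hint, and in this assay its number is lower. A moderate drop is expected, a number 15 percentage points lower from compound 1 to compound 4 (beyond the scatter), so compound 4 is estimated at 65%, between 35% and 90%.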

Compound 4, a percentage reported as inhibition, at one concentration (the size of the read-out at that concentration, not a potency): 89%
Estimate against measurement, compound 4: 24 percentage points below, within the range that was stated.
By their numbers in this assay, from the lowest: compound 2; then compounds 3, 1 and 4 (each within the scatter of the next).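

In this assay, 3-fluoro-4-methylphenyl in place of 3,5-dimethylphenyl on a sulfonyl sulfur gives a number 9 percentage points higher from compound 1 to compound 4 (within the scatter), so compound 1 and compound 4 cannot be told apart. For the compounds shown here, this single change shows that a fluorine can stand on this aryl group with the number staying high, which no earlier pair could show. Nothing available accounts for this result. Still open, on these data alone, is how a pyridine ring or a methoxyphenyl group on the sulfonyl sulfur would read in this assay.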